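Swapping a Difluorocyclohexyl for an Oxanyl Sulfone

A few compounds are considered here, and "the series" means these few. Any claim that something is new, unique, unknown or untested is made for them only; others in the source may bear on it.

Going by the values given here, compound 2 `O=C(NCc1ccc(S(=O)(=O)C2CCC(F)(F)CC2)cc1)N1Cc2ccncc2C1` carries the higher of the two numbers measured so far: in an assay on isolated protein for inhibition of Nicotinamide phosphoribosyltransferase (Homo sapiens), read by mass spectrometry, with stated times of 15 min and 30 min (a higher number here means a weaker inhibitor, a lower number a stronger inhibitor), compound 2 gives 78 nM, whereas compound 1 `O=C(NCc1ccc(S(=O)(=O)c2cccc(C(F)(F)F)c2)cc1)N1Cc2ccncc2C1` gives 8 nM. Among the compounds with values here, the only measured step, a 9.8-fold higher number from compound 1 to compound 2 (0.99 log units; beyond the scatter), exchanged an aromatic ring for a saturated one. Compound 3 `O=C(NCc1ccc(S(=O)(=O)C2CCOCC2)cc1)N1Cc2ccncc2C1` differs from compound 2 by oxan-4-yl in place of 4,4-difluorocyclohexyl on a sulfonyl sulfur. Within the data shown here, no measured step compares two saturated rings, so the direction of this change is untested. The step of a 1.5-fold higher number from compound 2 to compound 3 (0.19 log units; within the scatter) is therefore expected to stay within the scatter. For compound 3 the estimated value in this assay is 120 nM, with a range from 40 nM to 400 nM.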

Compound 3, half-maximal inhibitory concentration: 26 nM
Estimate against measurement, compound 3: 4.6-fold (0.66 log units) above; the whole stated range lies above it.
By their numbers in this assay, from the lowest: compound 1; then compound 3; then compound 2.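

In this assay, oxan-4-yl on the sulfonyl sulfur gives a 3.0-fold lower number from compound 2 to compound 3 (0.48 log units; beyond the scatter), so the choice between two saturated rings matters here, not only the choice of aromatic or saturated. Replacing 3-(trifluoromethyl)phenyl with oxan-4-yl still gives a 3.3-fold higher number from compound 1 to compound 3 (0.51 log units; beyond the scatter), so this saturated ring does not match the aromatic group. Nothing shown explains either difference. Going by these compounds, it remains open whether a saturated ring carrying an amine, such as piperidin-4-yl, or an open chain such as 2-methoxyethyl would follow oxan-4-yl.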